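Swapping the sulfonyl aryl group: compound 3 to compound 4

The compounds below may be only part of what the source reports. "The series", "measured", "known", "first", "only" and "open" are said of these compounds alone.

Measured compounds:
- compound 1, `CN1CCC(N(C)C(=O)C2CN(S(=O)(=O)c3cccc4ccccc34)c3ccccc32)CC1`: 31.6 nM
- compound 2, `CN1CCC(N(C)C(=O)C2CN(S(=O)(=O)c3ccc4ccccc4c3)c3ccccc32)CC1`: 25.1 nM
- compound 3, `CN1CCC(N(C)C(=O)C2CN(S(=O)(=O)C3=CC4CCOC4C=C3)c3ccccc32)CC1`: 31.6 nM

All three share a core and differ only in the group attached to the sulfonyl sulfur. In a functional assay on CHO cells for antagonist activity at 5-hydroxytryptamine receptor 6 (Homo sapiens), read by FLIPR (a lower number here means a stronger inhibitor, a higher number a weaker inhibitor), compound 3 stands level with compound 1, the two together giving the highest numbers of the three; the steps of no change at the digits printed from compound 1 to compound 3 (within the scatter) and a 1.3-fold higher number from compound 2 to compound 3 (0.10 log units; within the scatter) are both within the scatter, as is a 1.3-fold lower number from compound 1 to compound 2 (0.10 log units; within the scatter).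

Compound 4, `Cc1c(S(=O)(=O)N2CC(C(=O)N(C)C3CCN(C)CC3)c3ccccc32)sc2ccc(Cl)cc12`, is not yet measured. It differs from compound 3 in one place: a group of 11 heavy atoms (9 carbon, 1 sulfur, 1 chlorine; one five-membered aromatic ring with 1 hetero atom, one six-membered aromatic ring of carbon only) in place of a group of 9 heavy atoms (8 carbon, 1 oxygen; one five-membered non-aromatic ring with 1 hetero atom, one six-membered non-aromatic ring of carbon only), on a sulfonyl sulfur. The earlier steps shown here at this same position exchanged one bicyclic group for another and left this assay unchanged, so a step of similar size is expected here: a 1.1-fold lower number from compound 3 to compound 4 (0.02 log units; within the scatter) is the estimate, no change beyond the scatter in either direction. Compound 4 is therefore expected to give about 30 nM, with a range from 10 nM to 100 nM.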

Compound 4, inhibition constant: 63.1 nM
Compound 4: the middle estimate sits 2.1-fold (0.32 log units) below what was measured; the measured number falls inside the stated range.
By their numbers in this assay, from the lowest: compounds 2, 1, 3 and 4 (each within the scatter of the next, the first and the last beyond it).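

Going by these compounds alone, compound 4 gives the first step at this position on the sulfonyl sulfur that lies beyond the scatter in this assay, a modest one (a 2.5-fold higher number from compound 2 to compound 4 (0.40 log units; beyond the scatter)). The other two steps (a 2.0-fold higher number from compound 3 to compound 4 (0.30 log units; within the scatter) and a 2.0-fold higher number from compound 1 to compound 4 (0.30 log units; within the scatter)) stay within the scatter, so the 5-chloro-3-methyl-1-benzothiophen-2-yl group separates from naphthalen-2-yl but not from naphthalen-1-yl or the group of compound 3. Nothing available here accounts for this one separation.

The chlorine and the methyl enter together in compound 4, so the compounds shown leave open what each contributes on its own. Also open, going by these compounds, is how a plain phenyl ring, or a group carrying an amine or a carboxylic acid, would read on this sulfonyl sulfur in this assay.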